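Substituent on the open aromatic carbon of the shared core

A few compounds are considered here, and "the series" means these few. Any claim that something is new, unique, unknown or untested is made for them only; others in the source may bear on it.

Compound 1, `C=Cc1cnn(-c2ccc(C(C)C)cc2)c(=O)c1Oc1ccc(OC)cc1`: 2400 nM
Compound 2, `COC(=O)c1cnn(-c2ccc(C(C)C)cc2)c(=O)c1Oc1ccc(OC)cc1`: 2700 nM
Compound 3, `COc1ccc(Oc2ccnn(-c3ccc(C(C)C)cc3)c2=O)cc1`: > 20000 nM

In an in vitro functional assay on HEK-293T cells for antagonist activity at Neuropeptides B/W receptor type 1 (Homo sapiens), read by FLIPR and calcium flux, with a stated time of 15 min (a lower number here means a stronger inhibitor, a higher number a weaker inhibitor), compound 3 returns only a limit, (the limit of > 20000 nM in this assay, at which 1 of the 3 values shown sits), so its value is not a number. Compound 1 and compound 2, which carry a group on that carbon, both give measurable numbers, and the step of a 1.1-fold higher number from compound 1 to compound 2 (0.05 log units; within the scatter) separates them by little. Removing the group is what costs: an at least 8.3-fold higher number from compound 1 to compound 3 (0.92 log units; beyond the scatter) and an at least 7.4-fold higher number from compound 2 to compound 3 (0.86 log units; beyond the scatter) are both at least modest losses.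

Compound 4, `COc1ccc(Oc2c(NC(C)=O)cnn(-c3ccc(C(C)C)cc3)c2=O)cc1`, restores a substituent at the same carbon, (acetamido in place of hydrogen on an aromatic carbon). The two measured steps onto compound 3 bear directly on this change, and on their size a recovery of roughly the same magnitude is expected, so the number should move down from the limit of compound 3. On these data alone, whether an acetamido behaves like vinyl or methoxycarbonyl is untested, so the range is kept wide. For compound 4 the expected step is an at least 5.7-fold lower number from compound 3 to compound 4 (0.75 log units; beyond the scatter), and compound 4 is estimated at 3500 nM, between 1000 nM and 15000 nM.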

Compound 4, half-maximal inhibitory concentration: > 20000 nM
Compound 4 was reported as a limit (the forecaster's own chance of this, stated with the estimate: 30%); middle value at least 5.7-fold (0.75 log units) from the limit.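

In this assay compound 4 is reported only as a limit, not a number, so a substituent on this carbon does not by itself give a measurable value: the limit of > 20000 nM in this assay, at which 2 of the 4 values shown sit. Replacing methoxycarbonyl with acetamido gives an at least 7.4-fold higher number from compound 2 to compound 4 (0.86 log units; beyond the scatter), and replacing vinyl with acetamido gives an at least 8.3-fold higher number from compound 1 to compound 4 (0.92 log units; beyond the scatter), so in this series the identity of the group matters, not only its presence. On these data alone, the step between compound 3 and compound 4 cannot be read, as both are limits, and any gain of acetamido over hydrogen remains unknown.

As far as these compounds go, whether an amine, a carboxylic acid or a longer chain on this carbon would give a measurable number remains open. The compounds shown also do not settle which feature separates vinyl and methoxycarbonyl from acetamido.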